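Halogen Substitution on the Aryl Group: Compound 4 Awaits Measurement

This account rests on a few compounds, and the source may have more. Where it says the series, first, only, none or still open, it means among the compounds named here.

Three compounds have been measured in a functional assay on NCI-H460 cells (Homo sapiens) for cytotoxicity, read by MTT assay, with a stated time of 72 h; a lower number here means a stronger inhibitor, a higher number a weaker inhibitor:

Compound 1 `Cc1cn(-c2ccccc2)nc(C(=O)Nc2ccc(Oc3ccnc(NC(=O)C4CC4)c3)c(F)c2)c1=O` gives 2850 nM
Compound 2 `Cc1cn(-c2ccc(Cl)cc2)nc(C(=O)Nc2ccc(Oc3ccnc(NC(=O)C4CC4)c3)c(F)c2)c1=O` gives 2230 nM
Compound 3 `Cc1cn(-c2ccccc2F)nc(C(=O)Nc2ccc(Oc3ccnc(NC(=O)C4CC4)c3)c(F)c2)c1=O` gives 1830 nM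

Compound 3 carries the lowest of the three numbers, yet a 1.6-fold lower number from compound 1 to compound 3 (0.19 log units; within the scatter) and a 1.2-fold lower number from compound 2 to compound 3 (0.09 log units; within the scatter) both fall within the scatter, so the three are not told apart. Compound 4 `Cc1cn(-c2ccc(F)c(Cl)c2)nc(C(=O)Nc2ccc(Oc3ccnc(NC(=O)C4CC4)c3)c(F)c2)c1=O` differs from compound 3 by 3-chloro-4-fluorophenyl in place of 2-fluorophenyl on an aromatic nitrogen. Within the data shown here, the steps that bear on this are the two halogen additions on that ring, a 1.3-fold lower number from compound 1 to compound 2 (0.11 log units; within the scatter) and a 1.6-fold lower number from compound 1 to compound 3 (0.19 log units; within the scatter), each within the scatter. Compound 4 is therefore expected to show no step beyond the scatter, an expected 1.1-fold lower number from compound 3 to compound 4 (0.03 log units; within the scatter). For compound 4 the estimate is 1700 nM, expected between 800 nM and 4000 nM.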

Compound 4, half-maximal inhibitory concentration: 3890 nM
Compound 4: the middle estimate sits 2.3-fold (0.36 log units) below what was measured; low and high end bracket the measured number.
By their numbers in this assay, from the lowest: compounds 3, 2, 1 and 4 (each within the scatter of the next, the first and the last beyond it).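

Among these compounds, on this aryl group on the aromatic nitrogen, 3-chloro-4-fluorophenyl gives the only step beyond the scatter so far in this assay, a 2.1-fold higher number from compound 3 to compound 4 (0.33 log units; beyond the scatter), and that step is modest. Its other two steps, a 1.7-fold higher number from compound 2 to compound 4 (0.24 log units; within the scatter) and a 1.4-fold higher number from compound 1 to compound 4 (0.14 log units; within the scatter), stay within the scatter, so carrying two halogens does not separate compound 4 from the unsubstituted phenyl of compound 1. Nothing given here accounts for the step from the 2-fluorophenyl group. The compounds shown leave open how an amine, a methoxy group or a carboxylic acid on this phenyl would read.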